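Acetyl Ester of the Naphthalen-2-yl Alkylidene Alcohol

A few compounds are considered here, and "the series" means these few. Any claim that something is new, unique, unknown or untested is made for them only; others in the source may bear on it.

Three compounds share a cyclic core with a ring hydroxy group and an exocyclic arylidene arm, and have been tested in a functional assay on P388 cells (Mus musculus) for inhibition, read by MTT assay; a lower number here means a stronger inhibitor, a higher number a weaker inhibitor. Compound 1 `OC1C#CCCCCC#C/C1=C\c1ccccc1` gives 25000 nM in this assay. Compound 2 `OC1C#CCCCCC#C/C1=C\c1cccc2ccccc12` gives 41000 nM in this assay. Compound 3 `OC1C#CCCCCC#C/C1=C\c1ccc2ccccc2c1` gives 3600 nM in this assay, the lowest of the three numbers, and its gaps to compound 1 and to compound 2 both lie beyond the usual scatter.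

Compound 4 `CC(=O)OC1C#CCCCCC#C/C1=C\c1ccc2ccccc2c1` differs from compound 3 in one place: acetyl in place of hydrogen on an oxygen on a saturated carbon, so the hydroxy becomes an acetoxy. Going by the values given here, no pair among the measured compounds shows this change, so its size in this assay is unknown from the data. Since the arylidene arm of compound 3 is kept, the number for compound 4 is expected to stay near that of compound 3, with a modest move towards a higher number considered the more likely outcome, and the step of a 1.5-fold higher number from compound 3 to compound 4 (0.18 log units; within the scatter) is therefore estimated to be small. Compound 4 is thus estimated to give 5500 nM, within a range from 1500 nM to 20000 nM.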

Compound 4, half-maximal inhibitory concentration: 2800 nM
Beside the measured number, compound 4's estimate is 2.0-fold (0.29 log units) above it; measured number inside the range.
By their numbers in this assay, from the lowest: compounds 4 and 3 (each within the scatter of the next); then compounds 1 and 2 (each within the scatter of the next).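

In this assay, replacing the hydroxy with an acetoxy gives a 1.3-fold lower number from compound 3 to compound 4 (0.11 log units; within the scatter), so this oxygen on a saturated carbon accepts an acetyl in place of its hydrogen without a change beyond the scatter. Compounds 1, 2 and 3 all carry the free hydroxy and differ only in the arylidene arm, so they could say nothing about this position; compound 4 shows that, with the arm of compound 3, a free hydroxy is not needed to keep a number of this size. No measurement at hand explains this tolerance.

From the compounds shown here alone, whether the acetoxy is tolerated in the same way with the arms of compound 1 or compound 2 remains open. So does the effect of a methyl ether, a longer acyl chain such as butanoyl, or an amine at this position.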